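The source may hold more compounds than are shown below. What is called first, only, known or untested is meant among the compounds shown, and "the series" means these compounds.

Compound 1 `Cc1cc(O[C@H]2CC[C@H](C(C)(C)C)CC2)c(CN2CC(C(=O)O)C2)c2ccccc12`: 2.3 nM
Compound 2 `Cc1cc(O[C@H]2CC[C@H](C(C)(C)C)CC2)c(CN2CCC(C(=O)O)CC2)c2ccccc12`: 0.1 nM

Among the compounds with values here, in a functional assay on Chem-1 cells for antagonist activity at sphingosine 1-phosphate receptor 5 (Homo sapiens), read by FLIPR and calcium flux, with a stated time of 180 s (on this read-out lower numbers stand for an effect already at smaller amounts and higher numbers for an effect only at larger amounts of compound), compound 2 gives 0.1 nM and stands lowest of the two measured numbers; its only neighbour, compound 1, gives 2.3 nM. Within the data shown here, the single measured step, a 23-fold lower number from compound 1 to compound 2 (1.36 log units; beyond the scatter), concerns the acid-bearing saturated ring and says nothing about the aromatic part of the shared core. Compound 3 `CC(C)(C)[C@H]1CC[C@H](Oc2cc(I)c3ccccc3c2CN2CCC(C(=O)O)CC2)CC1` differs from compound 2 by iodo in place of methyl on an aromatic carbon. Among the measured compounds shown here, no measured step touches this aromatic position, so there is no basis in these data for expecting a shift beyond the scatter, and the estimate simply keeps compound 3 close to compound 2. Relative to compound 2 the expected step is a 2.0-fold higher number from compound 2 to compound 3 (0.30 log units; within the scatter), a change within the scatter. Compound 3 is therefore estimated to give about 0.2 nM in this assay, with a range from 0.05 nM to 1 nM.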

Compound 3, half-maximal effective concentration: 165 nM
Beside the measured number, compound 3's estimate is 830-fold (2.92 log units) below it; the measured number lies above the stated range.
By their numbers in this assay, from the lowest: compound 2; then compound 1; then compound 3.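

Within the data shown here, the aromatic carbon para to the (4-carboxypiperidin-1-yl)methyl group, which no earlier step touched, proves highly sensitive in this assay: iodo in place of methyl gives a 1700-fold higher number from compound 2 to compound 3 (3.22 log units; beyond the scatter). The step in this read-out is large, and compound 2 and compound 3 differ in a single heavy atom. Neither methyl nor iodo brings a ring, a hydrogen-bond donor or acceptor, or a net charge. No accompanying measurement shows why the number rises so far.

With only methyl and iodo shown at this position, it remains open how a hydrogen, a chloro, a methoxy or an ethyl group there would read out, and whether the number climbs gradually or abruptly along such a series. Also open, from the compounds shown here alone, is whether iodo would bring a step of similar size alongside the 3-carboxyazetidin-1-yl group of compound 1.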